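The source may report more compounds than this note shows. Statements on the series, on what has been measured and on what is new or still open speak of the compounds shown alone.

Measured so far:
Compound 1 `O=C(Nc1ccccc1)c1cccc(/C=C2\CC(=O)N(c3ccccc3)C2=O)c1` in an ADME assay on NCM460 cells (Homo sapiens) for cytotoxicity, read by MTT assay, with a stated time of 72 h (a higher number here means a weaker inhibitor, a lower number a stronger inhibitor), gives > 100000 nM, a limit of the assay and not a number.
Compound 2 `CCc1ccc(NC(=O)c2cccc(/C=C3\CC(=O)N(c4ccccc4)C3=O)c2)cc1` gives > 100000 nM, again a limit rather than a number.
Compound 3 `Cc1ccc(NC(=O)c2cccc(/C=C3\CC(=O)N(c4ccccc4)C3=O)c2)cc1C` gives > 100000 nM, which is likewise a limit.

Compound 3 therefore stands only at a limit, and it shares that position with both other compounds: the limit of > 100000 nM in this assay, at which 3 of the 3 values shown sit. The three measured compounds differ only in the group carried on the amide-type nitrogen, yet none of the steps among them can be read. Going by these compounds, the step that the two limits leave unreadable from compound 1 to compound 2, the step that the two limits leave unreadable from compound 1 to compound 3 and the step that the two limits leave unreadable from compound 2 to compound 3 each run between two limits, so their sizes remain unknown.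

Compound 4 `O=C(Nc1ccc(OC(F)F)cc1)c1cccc(/C=C2\CC(=O)N(c3ccccc3)C2=O)c1` has not been measured yet. It differs from compound 3 in one place: 4-(difluoromethoxy)phenyl in place of 3,4-dimethylphenyl on an amide-type nitrogen. Among the compounds with values here, no measured step gives a readable size, and nothing among the three measured compounds points to a shift away from the limit. In this assay compound 4 is expected to land at the same limit, with an estimated value of 150000 nM and a range from 50000 nM to 500000 nM. The expected step that the limit leaves unreadable from compound 3 to compound 4 is thus no change beyond the scatter.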

Compound 4, half-maximal inhibitory concentration: > 100000 nM
Compound 4 ended at the assay's limit (the forecaster's own chance of this, stated with the estimate: 85%); the middle value is on the limit's open side.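

In this assay compound 4 gives > 100000 nM, which is a limit of the assay and not a number. The steps to compound 4 from compound 1, compound 2 and compound 3 therefore cannot be read, because all four compounds share one limit: the limit of > 100000 nM in this assay, at which 4 of the 4 values shown sit.

The compounds shown leave open what size of effect, if any, each change on the amide-type nitrogen has in this assay.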